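The compounds below may be only part of what the source reports. "The series", "measured", "known", "first", "only" and "open" are said of these compounds alone.

Two members of the series have been measured in an assay on SH-EP1 cells for displacement of a labelled ligand from Neuronal acetylcholine receptor; alpha4/beta2 (Homo sapiens), read by scintillation counting (on this read-out lower numbers stand for stronger inhibition and higher numbers for weaker inhibition), so far. Compound 1 `O=C(C1CC1)N1CC2CC1CN2` gives 2800 nM in this assay. Compound 2 `CCC(=O)N1CC2CC(C1)N2` gives 6 nM in this assay, the lowest of the two numbers; compound 1 stands far higher, a gap well beyond the scatter of repeated measurements. The two compounds differ in both core and acyl group, so the two values cannot be traced to any single change.

Compound 3 `CC(C)C(=O)N1CC2CC(C1)N2` keeps the core of compound 2 and differs from it only in the acyl chain: methyl in place of hydrogen on a saturated chain carbon bound to a carbonyl carbon and a saturated chain carbon, which one bond further out reads ethyl to isopropyl. For the measured compounds named here, no measured pair carries this change, so the size of the step in this assay has to be estimated without direct precedent. On the numbers available the step is expected to be modest and to go toward a higher number, probably not far outside the scatter, and the expected step is a 2.5-fold higher number from compound 2 to compound 3 (0.40 log units; beyond the scatter). Compound 3 is accordingly estimated to give about 15 nM in this assay, with a range from 4 nM to 60 nM.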

Compound 3, inhibition constant: 130 nM
For compound 3 the middle estimate is 8.7-fold (0.94 log units) below the measured one; measured number outside the range, above it.
By their numbers in this assay, from the lowest: compound 2; then compound 3; then compound 1.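

In this assay, the first step read at a single place in the series shows that the acyl chain on the core of compound 2 is highly sensitive to branching: methyl in place of hydrogen on a saturated chain carbon bound to a carbonyl carbon and a saturated chain carbon gives a 22-fold higher number from compound 2 to compound 3 (1.34 log units; beyond the scatter). Ethyl to isopropyl is thus a large change in this assay, even though only a single methyl enters, and the direction of the step favours the unbranched ethyl chain of the two compared. Nothing available accounts for the size of this step.

The compounds shown leave open whether the number keeps rising with a further methyl at this carbon, as in tert-butyl, or whether a smaller acetyl group or a longer unbranched propyl chain on the same core would stay close to compound 2. They also leave open how much of the high number of compound 1 belongs to its acyl group and how much to its core, since compound 1 differs from compound 2 and compound 3 in more than one place.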